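The compounds below may be only part of what the source reports. "The series", "measured", "known", "first", "only" and "open" are said of these compounds alone.

Measured so far in a functional assay on T47D cells (Homo sapiens) for antiproliferative activity, read by MTT assay, with a stated time of 48 h; a higher number here means a weaker inhibitor, a lower number a stronger inhibitor: compound 1 `c1ccc(Cn2c(-c3nc4ccccc4[nH]3)cc3ccccc32)cc1` gives 21500 nM, and compound 3 `c1ccc2[nH]c(-c3nc4ccccc4[nH]3)cc2c1` gives 6200 nM. For compound 2 `BrC1=CN2NC(c3cc4ccccc4n3Cc3ccccc3)=NC2N=C1` the result in this assay stands as "not determined" (no result reported), so no number is available for it.

Compounds 1 and 3 share a core and differ in one place: hydrogen in place of benzyl on an aromatic nitrogen. This gave a 3.5-fold lower number from compound 1 to compound 3 (0.54 log units; beyond the scatter). The core of compound 2 differs from that of compound 1, but the difference between the two cores is not broken down here.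

Compound 4 `BrC1=CN2NC(c3cc4ccccc4[nH]3)=NC2N=C1` is still to be measured. It differs from compound 2 by hydrogen in place of benzyl on an aromatic nitrogen. This is the same kind of change as from compound 1 to compound 3, though the place differs: in one case the neighbouring ring atom bears a group of 9 heavy atoms, in the other a large group. Within the data shown here, compound 2 has no number, so no step can be carried over. The expectation rests only on compound 3, which gives 6200 nM, and on the direction of a 3.5-fold lower number from compound 1 to compound 3 (0.54 log units; beyond the scatter). Compound 4 is expected to reach about 6000 nM in this assay, estimated within 1000 nM to 40000 nM.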

Compound 4, half-maximal inhibitory concentration: 24400 nM
For compound 4 the middle estimate is 4.1-fold (0.61 log units) below the measured one; measured number inside the range.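

In this assay, among these compounds, compound 2 has no number, so no step to compound 4 can be read. Whether hydrogen in place of benzyl acts on this core as on the core of compound 1 stays open, and no evidence here offers a cause.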